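Cytotoxicity Outlook: From 4-(trifluoromethoxy)phenyl to 3-fluorophenyl

The source may report more compounds than this note shows. Statements on the series, on what has been measured and on what is new or still open speak of the compounds shown alone.

In an ADME assay on SK-OV-3 cells (Homo sapiens) for cytotoxicity, read by sulforhodamine B assay, with a stated time of 48 h, tested at 10 uM (on this read-out higher numbers stand for more inhibition at the one concentration tested (going by the name of the read-out) and lower numbers for less inhibition), compound 3 `COc1nc2ccc(Br)cc2cc1C(c1ccccc1)n1cc(-c2ccc(OC(F)(F)F)cc2)nn1` gives 14.8%, the highest of the three numbers shown, with compound 2 nearest and compound 1 furthest. Compound 2 `CCCCCc1cn(C(c2ccccc2)c2cc3cc(Br)ccc3nc2OC)nn1` gives 10.5%, while compound 1 `CCCCCCCCc1cn(C(c2ccccc2)c2cc3cc(Br)ccc3nc2OC)nn1` gives 2.06%. Compound 4 `COc1nc2ccc(Br)cc2cc1C(c1ccccc1)n1cc(-c2cccc(F)c2)nn1` differs from compound 3 by 3-fluorophenyl in place of 4-(trifluoromethoxy)phenyl on an aromatic carbon. Among the measured compounds shown here, the measured steps that touch this position are a number 12.7 percentage points higher from compound 1 to compound 3 (beyond the scatter) and a number 4.3 percentage points higher from compound 2 to compound 3 (within the scatter), both swapping a chain for an aryl group; no measured step exchanges one aryl group for another, so the effect of this change is unknown. Compound 4 is therefore expected to sit near compound 3, with an estimated a number 2.8 percentage points lower from compound 3 to compound 4 (within the scatter), and an estimated value of 12% in a range from 2% to 26%.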

Compound 4, a percentage reported as inhibition, at one concentration (the size of the read-out at that concentration, not a potency): 12.7%
Compound 4: middle estimate off by 0.7 percentage points, on the low side; low and high end bracket the measured number.
By their numbers in this assay, from the lowest: compounds 1, 2, 4 and 3 (each within the scatter of the next, the first and the last beyond it).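

In this assay, swapping one aryl group for another at this position gives a number 2.1 percentage points lower from compound 3 to compound 4 (within the scatter) and so separates 3-fluorophenyl from 4-(trifluoromethoxy)phenyl by no more than the scatter. Replacing the chains with 3-fluorophenyl gives a number 2.2 percentage points higher from compound 2 to compound 4 (within the scatter) but also a number 10.6 percentage points higher from compound 1 to compound 4 (beyond the scatter) and thus sets the octyl compound apart from the 3-fluorophenyl compound, while the pentyl compound stays within the scatter of it. No measurement at hand offers an explanation for these steps. The compounds shown leave open how an amine, a carboxylic acid or a chain shorter than pentyl would read at this position.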